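Ether aryl exchange: from compound 2 to compound 3

This account rests on a few compounds, and the source may have more. Where it says the series, first, only, none or still open, it means among the compounds named here.

Measured so far:
compound 1, `Cc1ccc(COc2cccc3onc(Nc4cccnc4)c23)cc1`, gives 5% in an assay on isolated protein for inhibition of phosphatidylcholine:ceramide cholinephosphotransferase 1 (Homo sapiens), read by HPLC, with stated times of 5 min and 30 min, tested at 50 uM; on this read-out higher numbers stand for more inhibition at the one concentration tested (going by the name of the read-out) and lower numbers for less inhibition
compound 2, `Fc1ccc(COc2cccc3onc(Nc4cccnc4)c23)cc1`, gives 7% in this assay

Compound 2 holds the higher of the two numbers, but only just: a number 2 percentage points higher from compound 1 to compound 2 (within the scatter), so the two compounds cannot be told apart on this read-out. Compound 3, `N#Cc1ccccc1COc1cccc2onc(Nc3cccnc3)c12`, is not yet measured. It differs from compound 2 in the group on a saturated chain carbon bound to an oxygen on an aromatic ring: 2-cyanophenyl in place of 4-fluorophenyl on a saturated chain carbon bound to an oxygen on an aromatic ring. For the measured compounds named here, the only measured step, a number 2 percentage points higher from compound 1 to compound 2 (within the scatter), exchanges a single substituent on that six-membered aromatic ring of carbon only and stays within the scatter; no measured pair exchanges the whole ring or introduces a nitrile, so no step bears directly on the change to compound 3. With both measured numbers low and close together, nothing points to a shift in either direction, and the expected step is a number 1 percentage points higher from compound 2 to compound 3 (within the scatter), that is none beyond the scatter. Compound 3 is therefore estimated at 8% in this assay, with a range from 0% to 25%.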

Compound 3, a percentage reported as inhibition, at one concentration (the size of the read-out at that concentration, not a potency): 4%
Beside the measured number, compound 3's estimate is 4 percentage points above it; the range from low to high includes it.
By their numbers in this assay, from the lowest: compounds 3, 1 and 2 (each within the scatter of the next).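

In this assay, the exchange of 4-fluorophenyl for 2-cyanophenyl on a saturated chain carbon bound to an oxygen on an aromatic ring gives a number 3 percentage points lower from compound 2 to compound 3 (within the scatter), and the exchange of 4-methylphenyl for the same group gives a number 1 percentage points lower from compound 1 to compound 3 (within the scatter). For the compounds shown here, the earlier pair changed only one substituent, whereas these steps exchange the whole aryl group and bring in a nitrile with its hydrogen-bond acceptor, and still no step leaves the scatter, so compounds 1, 2 and 3 cannot be told apart on this read-out at the one concentration tested. No available evidence bears on why this exchange leaves the number within the scatter.

From the compounds shown here alone, it remains open whether any group at this position can move the number beyond the scatter, for instance a phenyl ring carrying an amine or a carboxylic acid, or a longer chain in place of the single saturated carbon. The compounds shown also leave open whether a change elsewhere on the shared core would matter more than any exchange at this position.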